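The source may report more compounds than this note shows. Statements on the series, on what has been measured and on what is new or still open speak of the compounds shown alone.

Values so far in a functional assay on PC-3 cells (Homo sapiens) for inhibition, read by sulforhodamine B assay, with a stated time of 72 h (a higher number here means a weaker inhibitor, a lower number a stronger inhibitor), for the two measured compounds
compound 1 `Nc1sc(-c2ccc(Cl)cc2)c(-c2ccc(Cl)cc2)c1C(=O)NC1CCC1` gives 24800 nM in this series
compound 2 `CCOC(=O)Nc1sc(-c2ccc(Cl)cc2)c(-c2ccc(Cl)cc2)c1C(=O)NC1CC1` gives 27600 nM in this series

Compound 1 at 24800 nM sits within the scatter of compound 2 at 27600 nM and so holds no separate place in this small set. The next compound is compound 3 `CC(C)(C)NC(=O)c1c(N)sc(-c2ccc(Cl)cc2)c1-c1ccc(Cl)cc1` and its change from compound 1 reads tert-butyl in place of cyclobutyl on an amide-type nitrogen with tert-butyl in place of cyclobutyl on an amide-type nitrogen. The rest of the core of compound 1 stays as it is.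

Among the compounds with values here, no measured pair differs in one place only, so no direct step is available for sizing this change. The expectation therefore rests on the two values alone, with compound 1 at 24800 nM as the starting point. The expected result is a 1.0-fold higher number from compound 1 to compound 3 (0.00 log units; within the scatter) and this estimated step is none beyond the scatter, with no firm direction. In this assay compound 3 is estimated at 25000 nM with an expected range from 11000 nM to 50000 nM as its bounds.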

Compound 3, half-maximal inhibitory concentration: 15100 nM
Compound 3: middle estimate off by 1.7-fold (0.22 log units), on the high side; the measured number falls inside the stated range.
By their numbers in this assay, from the lowest: compounds 3, 1 and 2 (each within the scatter of the next).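

In this assay, within the data shown here, tert-butyl in place of cyclobutyl on an amide-type nitrogen gives a 1.6-fold lower number from compound 1 to compound 3 (0.22 log units; within the scatter), the first step between compounds that differ in one place. Both groups hold 4 carbon atoms and carry no hydrogen-bond donors or acceptors, so this exchange tests a ring of carbon only against a group with no ring, and the step stays within the scatter: at this read-out, the position shows no separable difference between the two groups. No measured property of either group bears on this result, so the step can be stated but not explained.

Going by these compounds, a single exchange between two groups of equal size says little about the position as a whole, and whether a much smaller group such as methyl, a longer chain such as n-hexyl, or a group with an amine or a carboxylic acid on the same nitrogen would move the number beyond the scatter remains open. The two 4-chlorophenyl groups and the free amino group of the core of compound 1 also remain open, as no step among the compounds shown tests any of them on its own.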